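Methoxy for methyl on a piperidine urea

The compounds below may be only part of what the source reports. "The series", "measured", "known", "first", "only" and "open" are said of these compounds alone.

Compound 1 `CC1CCC(C(=O)N2CC(c3nc(-c4cccc(Cl)c4)no3)C2)CC1` gives 1500 nM in an assay on HEK293 cells for positive allosteric modulation of metabotropic glutamate receptor 5 (Homo sapiens), read by FLIPR; a higher number here means that more compound is needed for the effect, a lower number that less compound is needed.
Compound 2 `CC1CCN(C(=O)N2CC(c3nc(-c4cccc(Cl)c4)no3)C2)C1` gives > 10000 nM, which is a limit of this assay and not a number.
Compound 3 `CC1CCN(C(=O)N2CC(c3nc(-c4cccc(Cl)c4)no3)C2)CC1` gives 865 nM in this assay.

All three compounds share the same core and differ only in the saturated ring joined to the carbonyl carbon. Compound 3 has the lowest of the two numbers that were obtained, and the gap to compound 1 is small: a 1.7-fold lower number from compound 1 to compound 3 (0.24 log units; within the scatter). The value of compound 2 sits at the limit of > 10000 nM in this assay, at which 1 of the 3 values shown sits, so the two steps that involve it, an at least 6.6-fold higher number from compound 1 to compound 2 (0.82 log units; beyond the scatter) and an at least 11-fold lower number from compound 2 to compound 3 (1.06 log units; beyond the scatter), show that the choice of ring can move the number a long way.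

Compound 4 `COC1CCN(C(=O)N2CC(c3nc(-c4cccc(Cl)c4)no3)C2)CC1` keeps the ring of compound 3 and changes only the group on it: methoxy in place of methyl on a saturated ring carbon. Within the data shown here, none of the measured steps touches this group; each of them exchanges the whole ring. Among the measured compounds shown here, there is therefore no step that shows how methyl against methoxy behaves here, and the expectation rests on the small change in size alone. The step is expected to stay within the scatter, perhaps leaning towards a slightly higher number: a 1.5-fold higher number from compound 3 to compound 4 (0.18 log units; within the scatter). Compound 4 is estimated at 1300 nM, with a range from 400 nM to 5000 nM.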

Compound 4, half-maximal effective concentration: > 10000 nM
Compound 4 gave a limit, no number; the forecaster's own chance of this, stated with the estimate: 10%; middle value at least 7.6-fold (0.88 log units) from the limit.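

In this assay, every earlier step exchanged the whole ring, whereas an at least 11-fold higher number from compound 3 to compound 4 (1.06 log units; beyond the scatter) keeps the ring and changes one group on a saturated ring carbon, three ring bonds from the ring nitrogen. This shows that the group at this position, and not only the choice of ring, can decide the result, and that methoxy in place of methyl is not a safe swap here even though it is a small change on paper. The 4-methoxypiperidin-1-yl group also compares poorly with the 4-methylcyclohexyl group of compound 1, as an at least 6.6-fold higher number from compound 1 to compound 4 (0.82 log units; beyond the scatter) shows, while compound 4 stands at a limit of the assay and not at a number, and with compound 2 at the same limit the step between those two cannot be read: the limit of > 10000 nM in this assay, at which 2 of the 4 values shown sit.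

The compounds shown leave open whether the oxygen itself matters or simply the longer group, a question that an ethyl group on the same ring carbon, with carbon where methoxy has oxygen, would help to settle. They also leave open how a hydroxyl group or a fluorine atom at this position would behave, and how far beyond the limit compound 4 really lies.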